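Swapping chloro for methoxy on the benzyl ring of compound 2

The compounds below may be only part of what the source reports. "The series", "measured", "known", "first", "only" and "open" are said of these compounds alone.

Measured compounds:
- compound 1, `COc1cccc(OC)c1OCCNCCOc1ccccc1OCc1cccc(Cl)c1`, 8.72
- compound 2, `COc1cccc(OC)c1OCCNCCOc1ccccc1OCc1ccc(Cl)cc1`, 9.11
- compound 3, `COc1cccc(OC)c1OCCNCCOc1ccccc1OCc1cccc([N+](=O)[O-])c1`, 9.28

In a functional assay on thoracic aorta for antagonist activity at Alpha-1D adrenergic receptor (Rattus norvegicus) (on this read-out higher numbers stand for higher potency (the scale is a negative logarithm) and lower numbers for lower potency), compound 2 stands second highest of the three; its nearest neighbour is compound 3, a number 0.17 log units higher from compound 2 to compound 3 (within the scatter), and its furthest is compound 1, a number 0.39 log units higher from compound 1 to compound 2 (beyond the scatter). Compound 4, `COc1ccc(COc2ccccc2OCCNCCOc2c(OC)cccc2OC)cc1`, differs from compound 2 by methoxy in place of chloro on an aromatic carbon. Going by the values given here, no measured step swaps chloro for methoxy. The closest guides are a number 0.56 log units higher from compound 1 to compound 3 (beyond the scatter) and a number 0.39 log units higher from compound 1 to compound 2 (beyond the scatter), both modest, showing that changes to this benzyl ring have so far moved this assay only a little. A step of similar size in either direction, or none beyond the scatter, is therefore expected, a number 0.21 log units lower from compound 2 to compound 4 (within the scatter). Compound 4 is expected to give 8.9, within 8.4 to 9.4.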

Compound 4, negative logarithm of the antagonist equilibrium constant: 9.21
Compound 4: the middle estimate sits 0.31 log units below what was measured; measured number inside the range.
By their numbers in this assay, from the lowest: compound 1; then compounds 2, 4 and 3 (each within the scatter of the next).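

In this assay, methoxy can take the place of chloro para to a large group with no shift beyond the scatter, a number 0.10 log units higher from compound 2 to compound 4 (within the scatter), so the extra oxygen and carbon cost nothing measurable here. The step of a number 0.07 log units lower from compound 3 to compound 4 (within the scatter) is also within the scatter, whereas the step of a number 0.49 log units higher from compound 1 to compound 4 (beyond the scatter) is beyond it, leaving compound 1 as the only one set apart. No measurement here explains why these groups are interchangeable.

Going by these compounds, what an amine or a carboxylic acid would do at this position remains open, and so does whether a longer chain such as ethoxy would be accepted as well as methoxy.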